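This account rests on a few compounds, and the source may have more. Where it says the series, first, only, none or still open, it means among the compounds named here.

Of the compounds shown here, two built on a shared core have been measured in an assay on isolated protein for inhibition of SRSF protein kinase 1 (Homo sapiens), tested at 1 uM; a higher number here means a weaker effect of the compound at the concentration tested, a lower number a stronger effect. Compound 1 `Cn1cc(/C=C2\C(=O)Nc3ccc(S(N)(=O)=O)cc32)c2ccccc21` gives 101% in this assay, and compound 2 `COc1ccc2c(c1)c(/C=C1\C(=O)Nc3ccc(S(=O)(=O)N(C)C)cc31)cn2C` gives 95%. Going by the values given here, compound 2 holds the smaller of the two numbers as written, but its only neighbour, compound 1, sits just slightly higher and the gap lies within the scatter, so the two readings cannot be told apart. The next compound, compound 3 `COc1ccc2c(c1)c(/C=C1\C(=O)Nc3ccc(S(N)(=O)=O)cc31)cn2C`, has not yet been measured in this assay. It differs from compound 2 in one place: amino in place of dimethylamino on a sulfonyl sulfur. No measured step of this kind exists among these compounds. The step is nevertheless expected to be none beyond the scatter, a number 3 percentage points higher from compound 2 to compound 3 (within the scatter), because compound 1 with the same sulfamoyl group gives 101% in this assay. Compound 3 is therefore expected to give about 98% in this assay, within a range from 85% to 110%.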

Compound 3, a percentage reported as activity, at one concentration (the size of the read-out at that concentration, not a potency): 99%
For compound 3 the middle estimate is 1 percentage points below the measured one, and the stated range covers the measured number.
By their numbers in this assay, from the lowest: compounds 2, 3 and 1 (each within the scatter of the next).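

In this assay, going by these compounds alone, amino in place of dimethylamino on a sulfonyl sulfur gives a number 4 percentage points higher from compound 2 to compound 3 (within the scatter), the first direct reading of this exchange, and it leaves the two compounds indistinguishable. With the sulfamoyl group held constant, methoxy in place of hydrogen on an aromatic carbon gives a number 2 percentage points lower from compound 1 to compound 3 (within the scatter), so this second single change cannot be told from the scatter either. Nothing available accounts for these readings.

Going by these compounds, whether another group on the sulfonyl sulfur, such as a morpholine or a longer chain ending in a carboxylic acid, would separate from these readings remains open. On these data alone, it is equally open whether a group other than methoxy on that aromatic carbon, such as chlorine or an amine, would give a reading beyond the scatter.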